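Dichlorophenyl Replacement on the Saturated Ring Carbon

This account rests on a few compounds, and the source may have more. Where it says the series, first, only, none or still open, it means among the compounds named here.

The measured compounds:
compound 1, `N#CC1=C(N)N(c2ccc(S(N)(=O)=O)cc2)C2=C(C(=O)CCC2)C1c1ccc(O)cc1`, activity 100%
compound 2, `COc1cc(CC2C(C#N)=C(N)N(c3ccc(S(N)(=O)=O)cc3)C3=C2C(=O)CCC3)ccc1O`, activity 100%
compound 3, `N#CC1=C(N)N(c2ccc(S(N)(=O)=O)cc2)C2=C(C(=O)CCC2)C1c1ccc([N+](=O)[O-])cc1`, activity 100%

In a functional assay on Ehrlich cells (Mus musculus) for antiproliferative activity, read by trypan blue exclusion, with a stated time of 2 h, tested at 100 ug/mL (on this read-out lower numbers stand for a weaker effect and higher numbers for a stronger effect at the one concentration tested), compound 3 stands level with compounds 1 and 2 at the digits shown. The three steps that join the measured compounds are all flat: no change at the digits printed from compound 1 to compound 2 (within the scatter), no change at the digits printed from compound 1 to compound 3 (within the scatter) and no change at the digits printed from compound 2 to compound 3 (within the scatter). Each of them exchanges the group on the saturated ring carbon or a substituent on its aromatic ring, and none of them moves the read-out beyond the scatter.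

Compound 4, `N#CC1=C(N)N(c2ccc(S(N)(=O)=O)cc2)C2=C(C(=O)CCC2)C1c1ccc(Cl)cc1Cl`, has not yet been measured. It differs from compound 3 in one place: 2,4-dichlorophenyl in place of 4-nitrophenyl on a saturated ring carbon. The step from compound 1 to compound 3, which also changes what is carried on that aromatic ring, and the steps that replace the whole group, bear directly on this change, and all were within the scatter. On that basis no step beyond the scatter is expected, no change at the digits printed from compound 3 to compound 4 (within the scatter), and the read-out of compound 4 is estimated at 100%, with a range from 85% to 100%.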

Compound 4, a percentage reported as activity, at one concentration (the size of the read-out at that concentration, not a potency): 95%
Compound 4: middle estimate off by 5 percentage points, on the high side; low and high end bracket the measured number.
By their numbers in this assay, from the lowest: compounds 4, 1, 2 and 3 (each within the scatter of the next).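

In this assay, within the data shown here, replacing 4-nitrophenyl with 2,4-dichlorophenyl on the saturated ring carbon gives a number 5 percentage points lower from compound 3 to compound 4 (within the scatter) and the other two comparisons read a number 5 percentage points lower from compound 2 to compound 4 (within the scatter) and a number 5 percentage points lower from compound 1 to compound 4 (within the scatter), so none of the three steps to compound 4 separates it from the earlier compounds. Compounds 1, 2 and 3 had shown this only for aromatic substituents containing oxygen, while compound 4 shows that the same holds for a group of carbon and chlorine alone, with no hydrogen-bond donors or acceptors. Nothing in the information at hand accounts for this flat result.

With all four compounds within the scatter of one another at a single concentration, the data give no ranking and leave open whether these groups would differ in the strength of their effect at lower concentrations. From the compounds shown here alone, it also remains open whether this position would accept an amine or a carboxylic acid on the aromatic ring, or a longer alkyl chain in place of the ring.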